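Swapping a large group for one fluorine

This account rests on a few compounds, and the source may have more. Where it says the series, first, only, none or still open, it means among the compounds named here.

Compound 1 `CC(O)(CS(=O)(=O)c1cccc(S(F)(F)(F)(F)F)c1)C(=O)Nc1ccc(S(F)(F)(F)(F)F)cc1`: 39900 nM
Compound 2 `CC(O)(CS(=O)(=O)c1cc(C(F)(F)F)cc(C(F)(F)F)c1)C(=O)Nc1ccc(S(F)(F)(F)(F)F)cc1`: 12700 nM
Compound 3 `CC(O)(CS(=O)(=O)c1ccc(S(F)(F)(F)(F)F)cc1)C(=O)Nc1cccc(S(F)(F)(F)(F)F)c1`: 12300 nM

All three were tested in a functional assay on CWR22R cells (Homo sapiens) for antiproliferative activity, read by propidium iodide staining, with a stated time of 96 h; on this read-out lower numbers stand for stronger inhibition and higher numbers for weaker inhibition. The values of compound 3 and compound 2 lie within the usual scatter of each other, while compound 1 has a higher number, beyond the scatter. Compound 4 `CC(O)(CS(=O)(=O)c1ccc(F)cc1)C(=O)Nc1cccc(S(F)(F)(F)(F)F)c1` differs from compound 3 by one fluorine atom in place of a group of 6 heavy atoms (5 fluorine, 1 sulfur; no ring), on an aromatic carbon: one fluorine atom replaces the larger group on an aromatic carbon, para to a large group. Going by the values given here, no measured pair differs in one place only, so the data offer no direct guide to this change. Among the compounds with values here, the only anchor is compound 3 at 12300 nM. A small shift toward a higher number is expected, with nothing beyond the scatter. The expected step is a 1.6-fold higher number from compound 3 to compound 4 (0.21 log units; within the scatter). The estimate for compound 4 is 20000 nM, with an expected range of 8000 nM to 50000 nM.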

Compound 4, half-maximal inhibitory concentration: 38900 nM
Compound 4: middle estimate off by 1.9-fold (0.29 log units), on the low side; low and high end bracket the measured number.
By their numbers in this assay, from the lowest: compounds 3 and 2 (each within the scatter of the next); then compounds 4 and 1 (each within the scatter of the next).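

Going by these compounds alone, at the aromatic carbon para to a large group, swapping the group of 6 heavy atoms (5 fluorine, 1 sulfur) for fluoro gives a 3.2-fold higher number from compound 3 to compound 4 (0.50 log units; beyond the scatter) in this assay and provides the first direct comparison at this position. The step lies beyond the usual scatter, so in this pair the larger group goes with stronger inhibition. Nothing available explains why the inhibition weakens. From the compounds shown here alone, whether chlorine, a nitrile or a methoxy group at this carbon would keep the number near that of compound 3 remains open.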